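From Naphthalen-1-yl to 3-Fluorophenyl in a Cell Assay

This account rests on a few compounds, and the source may have more. Where it says the series, first, only, none or still open, it means among the compounds named here.

Three related compounds have been tested in an ADME assay on HEK-293T cells (Homo sapiens) for inhibition, read by CCK-8 assay, with a stated time of 48 h; on this read-out higher numbers stand for weaker inhibition and lower numbers for stronger inhibition. Compound 1 (`CC(=O)Nc1ccc(S(=O)(=O)Oc2cccc(/C=C(\C#N)C(=O)Nc3nnc(-c4cccs4)s3)c2)cc1`) gives > 20000 nM, which is a limit of the assay and not a number. Compound 2 (`COc1ccc(Cc2nnc(NC(=O)/C(C#N)=C/c3ccccc3OS(=O)(=O)c3ccc(Cl)cc3)s2)cc1`) gives > 50000 nM, also a limit. Compound 3 (`COc1ccc(S(=O)(=O)Oc2ccccc2/C=C(\C#N)C(=O)Nc2nnc(Cc3cccc4ccccc34)s2)cc1`) gives > 50000 nM, again a limit, so its standing has no exact number. Compound 4 (`COc1ccc(S(=O)(=O)Oc2ccccc2/C=C(\C#N)C(=O)Nc2nnc(Cc3cccc(F)c3)s2)cc1`) carries 3-fluorophenyl in place of naphthalen-1-yl on a saturated chain carbon bound to an aromatic carbon. For the measured compounds named here, no measured pair shows the size of such a swap. The expected step, a number no higher from compound 3 to compound 4 (the limit leaves the size open), is none beyond the scatter, and another limit is the likely report. For compound 4 the estimate is 50000 nM, with an expected range from 20000 nM to 100000 nM.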

Compound 4, half-maximal inhibitory concentration: > 50000 nM
Compound 4: a limit, no number; the forecaster's own chance of this, stated with the estimate: 85%; the middle value lies on the limit itself.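

Compound 3 and compound 4 each give only a limit of the assay, and no step can be read between them. From the compounds shown here alone, the size of any effect from putting 3-fluorophenyl in place of naphthalen-1-yl stays open.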